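A few compounds are considered here, and "the series" means these few. Any claim that something is new, unique, unknown or untested is made for them only; others in the source may bear on it.

Compound 1 `CC(C)C(NC(=O)NO)C(=O)NC1CCCCC1` and compound 2 `CC(C)C(NC(=O)NO)C(=O)NC1CCCC1` share one core, and compound 1 differs from compound 2 by cyclohexyl in place of cyclopentyl on an amide-type nitrogen. In a functional assay on SW-620 cells (Homo sapiens) for inhibition (on this read-out lower numbers stand for stronger inhibition and higher numbers for weaker inhibition), compound 1 gives only a limit, > 100000 nM. In this assay compound 2 likewise gives only a limit, > 100000 nM. Both of these values sit at the limit of > 100000 nM in this assay, at which 2 of the 3 values shown sit, so the measured step is a step that the two limits leave unreadable from compound 2 to compound 1. Compound 3 `CC(C)C(NC(=O)n1nnc2ccccc21)C(=O)NC1CCCC1` is built on a different core; how the two cores differ is not broken down here. In this assay compound 3 gives only a limit, > 200000 nM, which is the limit of > 200000 nM in this assay, at which 1 of the 3 values shown sits. Compound 4 `CC(C)C(NC(=O)n1nnc2ccccc21)C(=O)NC1CCCCC1` has not yet been measured in this assay. It differs from compound 3 by cyclohexyl in place of cyclopentyl on an amide-type nitrogen, the same change that separates compound 1 from compound 2. With all three known values being limits, the change has never produced a readable number here. In this assay the step is expected to be a number no higher from compound 3 to compound 4 (the limit leaves the size open), resting on the unreadable a step that the two limits leave unreadable from compound 2 to compound 1 and on the limit of compound 3, > 200000 nM. Compound 4 is therefore estimated at 200000 nM, within a range from 50000 nM to 1000000 nM, most likely reported only as a limit.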

Compound 4, half-maximal inhibitory concentration: > 100000 nM
Compound 4: a limit, no number; the forecaster's own chance of this, stated with the estimate: 85%; the middle value does not contradict the limit.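

In this assay compound 4 gives only a limit, > 100000 nM. Compound 3 also gives only a limit, > 200000 nM, so no step can be read between compound 3 and compound 4. The compounds shown leave open whether cyclohexyl in place of cyclopentyl on an amide-type nitrogen changes inhibition at all on either core.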